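The source may hold more compounds than are shown below. What is called first, only, known or untested is meant among the compounds shown, and "the series" means these compounds.

Measured compounds in an ADME assay on L02 cells (Homo sapiens) for antiproliferative activity, read by MTT assay, with a stated time of 48 h; a lower number here means a stronger inhibitor, a higher number a weaker inhibitor:
compound 1 `CCn1c(C(=O)NCCN(C)C)ccc1C(CC)(CC)c1ccc(OCCC(O)(CC)CC)c(C)c1` gives 990 nM
compound 2 `CCN(CC)CCNC(=O)c1ccc(C(CC)(CC)c2ccc(OCCC(O)(CC)CC)c(C)c2)n1CC` gives 2290 nM
compound 3 `CCn1c(C(=O)NCCN)ccc1C(CC)(CC)c1ccc(OCCC(O)(CC)CC)c(C)c1` gives 2940 nM

Compound 3 has the highest number of the three; compound 2 sits within the scatter of it, and compound 1 is separated from it by a 3.0-fold higher number from compound 1 to compound 3 (0.47 log units; beyond the scatter). Compound 4 `CCn1c(C(=O)N(C)CCO)ccc1C(CC)(CC)c1ccc(OCCC(O)(CC)CC)c(C)c1` differs from compound 3 by (2-hydroxyethyl)(methyl)amino in place of (2-aminoethyl)amino on a carbonyl carbon. The measured steps, a 2.3-fold higher number from compound 1 to compound 2 (0.36 log units; beyond the scatter) and a 1.3-fold higher number from compound 2 to compound 3 (0.11 log units; within the scatter), all change the terminal amine on that chain and stay modest or within the scatter; none swaps the amine for a hydroxyl or methylates the amide nitrogen, so they bear only loosely on this step. In this assay the expectation is therefore a step of no more than modest size, a 1.2-fold higher number from compound 3 to compound 4 (0.08 log units; within the scatter), with no direction established beyond the scatter. Compound 4 is estimated at 3500 nM, range 1500 nM to 8000 nM.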

Compound 4, half-maximal inhibitory concentration: 2050 nM
The estimate for compound 4 lay 1.7-fold (0.23 log units) above the measured number, within the range that was stated.
By their numbers in this assay, from the lowest: compound 1; then compounds 4, 2 and 3 (each within the scatter of the next).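

In this assay the change at this carbonyl carbon to (2-hydroxyethyl)(methyl)amino gives a 1.4-fold lower number from compound 3 to compound 4 (0.16 log units; within the scatter) and also a 1.1-fold lower number from compound 2 to compound 4 (0.05 log units; within the scatter) so a basic terminal amine is not required to match these two compounds. Within the data shown here, compound 1 alone stays apart, with a 2.1-fold higher number from compound 1 to compound 4 (0.32 log units; beyond the scatter) as the only step here beyond the scatter. No measurement available here accounts for these numbers.

The hydroxyl and the methyl on the amide nitrogen enter together, so their separate contributions remain unresolved. From the compounds shown here alone, whether a carboxylic acid, a morpholine or a longer chain at this carbonyl carbon would shift the number also remains open.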